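The source may report more compounds than this note shows. Statements on the series, on what has been measured and on what is new or still open speak of the compounds shown alone.

Three compounds built on one shared core differ only in the group carried on an oxygen on an aromatic ring. Compound 1 `CCOc1cc(CNc2nc3c(N)ncnc3n2[C@@H]2O[C@H](CO)[C@@H](O)[C@H]2O)ccc1-c1ccccc1` bears a short chain there, compound 2 `CC(C)Oc1cc(CNc2nc3c(N)ncnc3n2[C@@H]2O[C@H](CO)[C@@H](O)[C@H]2O)ccc1-c1ccccc1` an isopropyl, and compound 3 `Nc1ncnc2c1nc(NCc1ccc(-c3ccccc3)c(OCCCCO)c1)n2[C@@H]1O[C@H](CO)[C@@H](O)[C@H]1O` a 4-hydroxybutyl. In an assay on COS-7 cells for inhibition of sodium/nucleoside cotransporter 2 (Homo sapiens), read by scintillation counting (a lower number here means a stronger inhibitor, a higher number a weaker inhibitor), compound 1 gives 2300 nM, compound 2 gives 10400 nM, and compound 3 gives 940 nM, the lowest number of the three. Among the steps, a 4.5-fold higher number from compound 1 to compound 2 (0.66 log units; beyond the scatter), whereas a 2.4-fold lower number from compound 1 to compound 3 (0.39 log units; beyond the scatter) and an 11-fold lower number from compound 2 to compound 3 (1.04 log units; beyond the scatter). Compound 4 `Nc1ncnc2c1nc(NCc1ccc(-c3ccccc3)c(OCCCCCO)c1)n2[C@@H]1O[C@H](CO)[C@@H](O)[C@H]1O` differs from compound 3 by hydroxymethyl in place of hydroxy on a saturated chain carbon, four bonds along the chain from an oxygen on an aromatic ring. The step that most resembles this one is the chain lengthening with a hydroxyl at its end, from compound 1 to compound 3, which was modest in size. Because a 2.4-fold lower number from compound 1 to compound 3 (0.39 log units; beyond the scatter) came from growing a hydroxyl-ended chain, one more carbon is expected to give at most a small further lowering in this assay, possibly none beyond the scatter. Compound 4 is therefore estimated at 700 nM, with a likely range from 300 nM to 1800 nM. The expected step is a 1.3-fold lower number from compound 3 to compound 4 (0.13 log units; within the scatter).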

Compound 4, half-maximal inhibitory concentration: 1600 nM
Compound 4: the middle estimate sits 2.3-fold (0.36 log units) below what was measured; low and high end bracket the measured number.
By their numbers in this assay, from the lowest: compounds 3, 4 and 1 (each within the scatter of the next, the first and the last beyond it); then compound 2.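

Adding one more carbon to the hydroxyl-ended chain, which turns 4-hydroxybutyl into 5-hydroxypentyl, gives a 1.7-fold higher number from compound 3 to compound 4 (0.23 log units; within the scatter), so the two compounds cannot be told apart at this position. The 5-hydroxypentyl chain also cannot be told apart from the short chain, with a 1.4-fold lower number from compound 1 to compound 4 (0.16 log units; within the scatter), although compound 3 did stand clear of compound 1. The new chain does stand clear of the isopropyl group, with a 6.5-fold lower number from compound 2 to compound 4 (0.81 log units; beyond the scatter), and nothing measured here explains these numbers.

The compounds shown leave open whether a longer chain, or a chain ending in an amine or a carboxylic acid instead of a hydroxyl, would give a clearly lower number. They also leave open what a plain pentyl chain would give, which would show how much the end hydroxyl matters.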